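Ethoxy for Ethyl on Two Inactive Imide Benzamides

The source may report more compounds than this note shows. Statements on the series, on what has been measured and on what is new or still open speak of the compounds shown alone.

Measured in an ADME assay on HCT-116 cells (Homo sapiens) for cytotoxicity, read by MTT assay, with a stated time of 72 h; on this read-out lower numbers stand for stronger inhibition and higher numbers for weaker inhibition:
Compound 1, `CCCCCN1C(=O)C/C(=C\c2cccc(C(=O)Nc3ccc(C)cc3)c2)C1=O`, gives > 100000 nM.
Compound 2, `CCc1ccc(NC(=O)c2cccc(/C=C3\CC(=O)N(c4ccccc4)C3=O)c2)cc1`, gives > 100000 nM.

The value given for compound 1 is a limit of this assay and not a number. The value given for compound 2 is likewise a limit and not a number. What the two results have in common is the limit of > 100000 nM in this assay, at which 2 of the 2 values shown sit. Going by the values given here, no step between two measured compounds is available, and compound 2 therefore stands only at a limit, with no number that places it against compound 1.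

Compound 3, `CCOc1ccc(NC(=O)c2cccc(/C=C3\CC(=O)N(c4ccccc4)C3=O)c2)cc1`, is not yet measured in this assay. It differs from compound 2 by ethoxy in place of ethyl on an aromatic carbon.

With both measured compounds sitting at a limit, there is no basis for expecting this change to move the read-out in either direction beyond the usual scatter. Compound 3 is therefore expected to give about 100000 nM in this assay, within a range from 30000 nM to 300000 nM, and the expected step of a number no higher from compound 2 to compound 3 (the limit leaves the size open) is none worth noting. Most likely compound 3 will again be reported only as a limit.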

Compound 3, half-maximal inhibitory concentration: 84800 nM
For compound 3 the middle estimate is 1.2-fold (0.07 log units) above the measured one; low and high end bracket the measured number.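

In this assay, ethoxy in place of ethyl on an aromatic carbon, para to a large group, gives an at least 1.1-fold lower number from compound 2 to compound 3 (0.07 log units; that floor lies within the scatter) and yields the only actual number among the three compounds shown. Compound 2 stands at a limit, so this step has a floor but no fixed size, and the true difference may lie within the usual scatter or beyond it. What the change does show is that a swap bringing in one oxygen and one hydrogen-bond acceptor at this position can give a readable value in this assay, although compound 3 at 84800 nM still sits high on the scale, where higher numbers stand for weaker inhibition.

As far as these compounds go, it remains open whether the oxygen itself matters at this position, and a methoxy group, a longer alkoxy chain, a hydroxyl or an amine in the same place would each bear on that question. From the compounds shown here alone, it also remains open whether the same swap would give a number on the core of compound 1, which differs from compound 3 in more than one place and so offers no direct comparison.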